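This account rests on a few compounds, and the source may have more. Where it says the series, first, only, none or still open, it means among the compounds named here.

Measured compounds:
- compound 1, `Cc1cccc(OCC(=O)Nc2nc(-c3ccccc3)n[nH]2)c1`, with 1500 nM in an assay on CHO cells for displacement of a labelled ligand from adenosine receptor A3 (Homo sapiens), read by scintillation counting, with a stated time of 60 min; a higher number here means a weaker inhibitor, a lower number a stronger inhibitor
- compound 2, `O=C(COc1ccc2c(c1)CCC2)Nc1nc(-c2ccccc2)n[nH]1`, with 2200 nM in this assay

In this assay compound 1 gives the lowest of the two numbers shown, and compound 2 gives a value that lies within the usual scatter of it, so the two cannot be placed in order on these data. Compound 3, `Cc1cc(C)cc(OCC(=O)Nc2nc(-c3ccccc3)n[nH]2)c1`, is the compound yet to be measured. It differs from compound 1 by methyl in place of hydrogen on an aromatic carbon, so that the 3-methylphenyl becomes a 3,5-dimethylphenyl. Among the measured compounds shown here, no pair of measured compounds shows what such an added methyl does here, so the direction of the step cannot be drawn from the data. The step from compound 1 to compound 3 is therefore expected to be small, a 1.3-fold lower number from compound 1 to compound 3 (0.10 log units; within the scatter), and not clearly beyond the scatter. Compound 3 is accordingly estimated at 1200 nM, with a range from 400 nM to 3500 nM.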

Compound 3, inhibition constant: 2700 nM
Beside the measured number, compound 3's estimate is 2.3-fold (0.35 log units) below it, within the range that was stated.
By their numbers in this assay, from the lowest: compounds 1, 2 and 3 (each within the scatter of the next).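

In this assay, among the compounds shown here, the methyl that turns the 3-methylphenyl into a 3,5-dimethylphenyl gives a 1.8-fold higher number from compound 1 to compound 3 (0.26 log units; within the scatter), the first step that can be read at all. This aromatic carbon, meta to a large group and meta to a methyl group, therefore carries a methyl in place of hydrogen without a change that can be told from the scatter, though this single pair cannot show a direction. No available measurement explains the size of this step.

The compounds shown leave open whether a larger or differently built group at this carbon, such as an amine, a carboxylic acid or a longer alkyl chain, would give a step beyond the scatter. They also leave open whether a methyl on another carbon of this ring would behave in the same way.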